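The source may report more compounds than this note shows. Statements on the series, on what has been measured and on what is new or still open speak of the compounds shown alone.

Measured compounds so far:

compound 1, `N#CC1=C(N)Oc2c(c3nc4ccccc4nc3c3ccccc23)C12C(=O)N(Cc1cnnn1-c1ccc([N+](=O)[O-])cc1)c1ccccc12`: > 50000 nM in an ADME assay on HUVEC cells (Homo sapiens) for antiproliferative activity, read by MTT assay, with a stated time of 48 h (a lower number here means a stronger inhibitor, a higher number a weaker inhibitor), a limit of the assay and not a number.
compound 2, `CC(=O)Nc1ccc(-n2nncc2CN2C(=O)C3(C(C#N)=C(N)Oc4c3c3nc5ccccc5nc3c3ccccc43)c3ccccc32)cc1`: > 50000 nM in this assay, again a limit.
compound 3, `N#CC1=C(N)Oc2c(N)cc3nc4ccccc4nc3c2C12C(=O)N(Cc1cnnn1-c1ccc(Cl)cc1)c1ccccc12`: > 50000 nM in this assay, likewise a limit.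

Compound 3 thus stands only at a limit; every value shown in this assay is a limit, and the limit of > 50000 nM in this assay, at which 3 of the 3 values shown sit, holds for all three. For the measured compounds named here, the one step between measured compounds that differ in a single place, a step that the two limits leave unreadable from compound 1 to compound 2, cannot be read because both ends sit at the limit, so no measured step gives a size for any change.

The unmeasured compound 4, `N#CC1=C(N)Oc2c(N)cc3nc4ccccc4nc3c2C12C(=O)N(Cc1cnnn1-c1ccc([N+](=O)[O-])cc1)c1ccccc12`, differs from compound 3 by nitro in place of chloro on an aromatic carbon. Compound 1 carries the same nitro group and sits at the limit, and compound 3 with chloro sits at the limit, so the change bears on no readable step. The expectation for compound 4 is therefore a step that the limit leaves unreadable from compound 3 to compound 4, that is, no movement beyond the scatter and most likely another limit. The estimate for compound 4 in this assay is 80000 nM, with a range from 40000 nM to 200000 nM.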

Compound 4, half-maximal inhibitory concentration: > 50000 nM
Compound 4 gave a limit, no number; the forecaster's own chance of this, stated with the estimate: 85%; the middle value lies beyond the limit too.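

In this assay, no new step can be read between compound 3 and compound 4, because both sit at the same limit: the limit of > 50000 nM in this assay, at which 4 of the 4 values shown sit.

The compounds shown leave open whether any member of this series reaches a measurable value in this assay, and what size any single change on the shared core would have.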